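This account rests on a few compounds, and the source may have more. Where it says the series, first, only, none or still open, it means among the compounds named here.

Measured in a functional assay on BXPC-3 cells (Homo sapiens) for antiproliferative activity, read by MTT assay, with a stated time of 24 h; a higher number here means a weaker inhibitor, a lower number a stronger inhibitor:

- compound 1 `CCn1c(C(=O)NCCNC(=O)OC(C)(C)C)ccc1C(CC)(CC)c1ccc(OCS(=O)(=O)c2ccccc2)c(C)c1`: > 50000 nM (a limit)
- compound 2 `CCn1c(C(=O)N[C@@H](CO)CCO)ccc1C(CC)(CC)c1ccc(OCS(=O)(=O)c2ccccc2)c(C)c1`: > 50000 nM (a limit)
- compound 3 `CCn1c(C(=O)NCC(=O)O)ccc1C(CC)(CC)c1ccc(OCS(=O)(=O)c2ccccc2)c(C)c1`: > 50000 nM (a limit)

Compound 3 stands at > 50000 nM, which is a limit and not a number. It has no better placing in the series, where the whole picture so far is the limit of > 50000 nM in this assay, at which 3 of the 3 values shown sit.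

The next change gives compound 4 `CCn1c(C(=O)N[C@@H](C(=O)O)C(C)C)ccc1C(CC)(CC)c1ccc(OCS(=O)(=O)c2ccccc2)c(C)c1`, with isopropyl in place of hydrogen on a saturated chain carbon bound to an amide-type nitrogen and a carbonyl carbon. Carboxymethyl thus becomes 1-carboxy-2-methylpropyl.

The measured steps that bear on this all alter the group on the same amide-type nitrogen: a step that the two limits leave unreadable from compound 1 to compound 3, a step that the two limits leave unreadable from compound 2 to compound 3 and a step that the two limits leave unreadable from compound 1 to compound 2. None of them has a readable size, so they give no direction for the new group.

With no measured number to work from, no step beyond the scatter is expected in this assay (a number no higher from compound 3 to compound 4 (the limit leaves the size open)), and a further limit is the likeliest reading. The estimate for compound 4 is 50000 nM, with an expected range of 15000 nM to 100000 nM.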

Compound 4, half-maximal inhibitory concentration: 13900 nM
The estimate for compound 4 lay 3.6-fold (0.56 log units) above the measured number; measured number outside the range, below it.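

In this assay, among these compounds, isopropyl on a saturated chain carbon bound to an amide-type nitrogen and a carbonyl carbon gives the first readable step: an at least 3.5-fold lower number from compound 3 to compound 4 (0.55 log units; beyond the scatter). On the same amide-type nitrogen, 1-carboxy-2-methylpropyl in place of 3-hydroxy-1-(hydroxymethyl)propyl gives an at least 3.5-fold lower number from compound 2 to compound 4 (0.55 log units; beyond the scatter), and in place of 2-((tert-butoxycarbonyl)amino)ethyl it gives an at least 3.5-fold lower number from compound 1 to compound 4 (0.55 log units; beyond the scatter). The steps among compound 1, compound 2 and compound 3 cannot be read, and only compound 4 leaves the shared limit: the limit of > 50000 nM in this assay, at which 3 of the 4 values shown sit.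

Going by these compounds, whether the step holds for other groups on that carbon, such as methyl or benzyl, remains open. Also open, on these data alone, is whether it survives replacing the carboxy group with a methyl ester.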